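The source may report more compounds than this note shows. Statements on the series, on what has been measured and on what is new or still open speak of the compounds shown alone.

Compound 1 `Cn1nc(N)c2c(=O)[nH]c(-c3ccccc3)cc21` and compound 2 `Cn1nc(N)c2c(=O)[nH]c(-c3ccccn3)cc21` share one core, while compound 3 `Nc1c2c(=O)[nH]c(-c3ccccc3)cc2nn1-c1ccccc1` and compound 4 `Nc1c2c(=O)[nH]c(-c3ccccn3)cc2nn1-c1ccccc1` share another; how the two cores differ is not broken down here. In an assay on isolated protein for inhibition of MAP kinase-activated protein kinase 2 (Homo sapiens), read by mobility shift assay, tested at 30 uM (a higher number here means more inhibition at the concentration tested (going by the name of the read-out), a lower number less inhibition), compound 1 gives 37%. Compound 2 differs from compound 1 in a single place: pyridin-2-yl in place of phenyl on an aromatic carbon. That change produced a number 1 percentage points lower from compound 1 to compound 2 (within the scatter). On the second core, compound 3 gives 2% in this assay, and compound 2 gives 36%, so compound 3 sits far apart from both measured compounds of the first core, with its number the lowest of the three. Compound 4 differs from compound 3 by the same change, (pyridin-2-yl in place of phenyl on an aromatic carbon), and the surroundings of the place are described in identical words. Because the earlier step was a number 1 percentage points lower from compound 1 to compound 2 (within the scatter), the expected step is no change at the digits printed from compound 3 to compound 4 (within the scatter). Compound 4 is accordingly estimated at 2% in this assay, with a plausible range from -8% to 12%. This rests on one earlier pair only, and the measurement of compound 4 will show whether the change behaves alike on the second core.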

Compound 4, a percentage reported as inhibition, at one concentration (the size of the read-out at that concentration, not a potency): 4%
For compound 4 the middle estimate is 2 percentage points below the measured one; the measured number falls inside the stated range.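

On the second core, putting pyridin-2-yl in place of phenyl gave a number 2 percentage points higher from compound 3 to compound 4 (within the scatter) in this assay. Set beside the earlier pair, the change behaves alike on the two cores: the same change on two cores in this assay, a number 1 percentage points lower (within the scatter) from compound 1 to compound 2 and a number 2 percentage points higher (within the scatter) from compound 3 to compound 4, 3 percentage points apart, within the scatter of two such steps. For the compounds shown here, this rests on only two pairs, each read at a single concentration: it shows that the swap made no measurable difference on these two cores, but it does not show that the swap would be neutral on every core, and it gives no potency for any of the four compounds.

The compounds shown leave open whether a different group on this aromatic carbon, such as a carboxylic acid, an amine or a longer alkyl chain, would move the number beyond the usual scatter of the measurement. Also open, as far as these compounds go, is whether pyridin-2-yl and phenyl would still give matching numbers on a third core.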